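The compounds below may be only part of what the source reports. "The series", "measured", "known", "first", "only" and "open" are said of these compounds alone.

Measured in a functional assay on MCF7 cells (Homo sapiens) for cytotoxicity, read by sulforhodamine B assay, with a stated time of 48 h (a higher number here means a weaker inhibitor, a lower number a stronger inhibitor), so far:
Compound 1 `COc1ccc(/C=C/C(=O)c2cccc(-c3ccc(F)cc3)c2)cc1` gives 16400 nM
Compound 2 `COc1ccc(/C=C/C(=O)c2ccc(NC(C)=O)c(-c3ccc(F)cc3)c2)cc1OC` gives 15000 nM

Among the measured compounds shown here, compound 1 at 16400 nM and compound 2 at 15000 nM lie within the usual scatter of each other, so compound 1 cannot be ranked against its only neighbour. Compound 3 `COc1ccc(/C=C/C(=O)c2ccc(N)c(-c3ccc(F)cc3)c2)cc1` has not yet been measured. It departs from compound 1 in one place: amino in place of hydrogen on an aromatic carbon. For the measured compounds named here, no measured pair isolates this change, so this assay offers no direct precedent for it. Compound 2 differs from compound 1 in more than one place, yet compound 2 at 15000 nM stays within the scatter, and a large shift is therefore not expected. A slight move towards a lower number is expected, but none beyond the scatter. The estimated step is a 1.5-fold lower number from compound 1 to compound 3 (0.17 log units; within the scatter) and it remains tentative. Compound 3 is expected at 11000 nM, within an estimated range of 4500 nM to 26000 nM.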

Compound 3, half-maximal inhibitory concentration: 7580 nM
Compound 3: middle estimate off by 1.5-fold (0.16 log units), on the high side; measured number inside the range.
By their numbers in this assay, from the lowest: compounds 3, 2 and 1 (each within the scatter of the next, the first and the last beyond it).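

In this assay, amino in place of hydrogen on an aromatic carbon, ortho to a 4-fluorophenyl group and para to a large group, gives a 2.2-fold lower number from compound 1 to compound 3 (0.34 log units; beyond the scatter), a modest change but one that stands beyond the scatter. Among the compounds shown here, this is the first pair that isolates a single change at this carbon, and it shows that the added amino moves the number towards a stronger inhibitor rather than leaving it unchanged. No measurement shown here accounts for the shift.

The compounds shown leave open whether a hydroxyl group or a dimethylamino group on this same carbon would move the number as far as amino does. From the compounds shown here alone, it also remains open whether amino would give a step of similar size without the 4-fluorophenyl group present.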